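Dienone series: acetoxy for chloro on the aryl ring

A few compounds are considered here, and "the series" means these few. Any claim that something is new, unique, unknown or untested is made for them only; others in the source may bear on it.

Measured compounds:
compound 1 `CC(=C\c1ccccc1)/C=C1\CCC=CC1=O` — 3900 nM
compound 2 `O=C1C=CCC/C1=C\C(Br)=C\c1ccccc1` — reported only as a limit, > 10000 nM
compound 3 `O=C1C=CCC/C1=C\C=C\c1ccc(Cl)cc1` — 3200 nM

In a functional assay on Bel-7402 cells (Homo sapiens) for cytotoxicity, read by MTT assay, with a stated time of 72 h (on this read-out higher numbers stand for weaker inhibition and lower numbers for stronger inhibition), compound 3 gives the lowest of the two numbers shown. Its nearest neighbour is compound 1, whose value sits within the scatter of that of compound 3, so no order between the two can be read. For compound 2 this assay reports only a limit, not a number.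

Compound 4 `CC(=O)Oc1ccc(/C=C/C=C2\CCC=CC2=O)cc1` differs from compound 3 in one place: acetoxy in place of chloro on an aromatic carbon.

For the measured compounds named here, the only measured step, an at least 2.5-fold higher number from compound 1 to compound 2 (0.40 log units; beyond the scatter), concerns a substituent on the chain and not the aromatic ring; it sits partly on the limit noted in the limit of > 10000 nM in this assay, at which 1 of the 3 values shown sits, and so gives only a lower bound on its size. Going by the values given here, no measured step touches the aromatic carbon where the change from compound 3 to compound 4 occurs, so nothing in the data fixes its direction. The expected step of a 1.1-fold higher number from compound 3 to compound 4 (0.04 log units; within the scatter) is therefore no more than the scatter, with a wide range to allow for either direction.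

Compound 4 is estimated at 3500 nM in this assay, with a range from 1200 nM to 10000 nM.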

Compound 4, half-maximal inhibitory concentration: 3800 nM
For compound 4 the middle estimate is 1.1-fold (0.04 log units) below the measured one; the range from low to high includes it.
By their numbers in this assay, from the lowest: compounds 3, 4 and 1 (each within the scatter of the next). At a limit, above all of these: compound 2.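

In this assay, the aromatic carbon para to a large group now has a measured step of its own: a 1.2-fold higher number from compound 3 to compound 4 (0.07 log units; within the scatter). For the compounds shown here, this step lies within the scatter, so the exchange of chloro (1 heavy atom, 0 hydrogen-bond acceptors) for acetoxy (4 heavy atoms, 2 hydrogen-bond acceptors) gives no readable change here, and this position accepts the larger group on this read-out, whereas the only earlier step, on the chain, gave no information about the aromatic ring. Nothing measured on hand bears on why these two groups read alike.

The compounds shown leave open what a hydroxy group, an amine or a carboxylic acid on this aromatic carbon would give, and whether an ester with a longer chain in place of acetoxy would also stay within the scatter. They also leave open whether the exchange of chloro for acetoxy would read the same with methyl or bromo on the chain, as carried by the other two compounds.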